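This account rests on a few compounds, and the source may have more. Where it says the series, first, only, none or still open, it means among the compounds named here.

Measured so far:
compound 1 `COc1cc(-c2nn(-c3cccc(NC(=O)c4ccc(Cl)c(C(F)(F)F)c4)c3)cc2-c2ccncc2)ccc1Cl` — > 32500 nM
compound 2 `O=C(Nc1cccc(-n2cc(-c3ccncc3)c(-c3ccc(Cl)c(O)c3)n2)c1)Nc1cc(C(F)(F)F)cc(C(F)(F)F)c1` — 1570 nM

In a functional assay on SK-MEL-28 cells (Homo sapiens) for inhibition, read by sulforhodamine B assay, with a stated time of 48 h (a lower number here means a stronger inhibitor of growth, a higher number a weaker inhibitor of growth), compound 1 gives only a limit, > 32500 nM, not a measured number. Compound 2 gives 1570 nM in this assay, a number well inside the measurable range. Among the measured compounds shown here, no pair of measured compounds differs in a single place, so no measured step is available; compound 1 simply stands at the limit of > 32500 nM in this assay, at which 1 of the 2 values shown sits, and the two values together show only that compound 2 is a measurable inhibitor where compound 1 is not.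

Compound 3 `COc1cc(-c2nn(-c3cccc(NC(=O)Nc4cccc(C(F)(F)F)c4)c3)cc2-c2ccncc2)ccc1Cl` is the next compound for this assay. It differs from compound 1 by (3-(trifluoromethyl)phenyl)amino in place of 4-chloro-3-(trifluoromethyl)phenyl on a carbonyl carbon. The rest of the shared core of compound 1 is kept unchanged.

The step from compound 1 to compound 3 is expected to be sizeable and toward stronger growth inhibition, an at least 4.0-fold lower number from compound 1 to compound 3 (0.60 log units; beyond the scatter), beyond the usual scatter, because compound 2, which also carries an amino group on that carbonyl carbon, gives 1570 nM. Compound 3 is therefore estimated at 8000 nM, with a range of 2000 nM to 32500 nM, the upper end allowing that the assay may again report only a limit.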

Compound 3, concentration for total growth inhibition: 3350 nM
Beside the measured number, compound 3's estimate is 2.4-fold (0.38 log units) above it; the range from low to high includes it.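

In this assay, exchanging the 4-chloro-3-(trifluoromethyl)phenyl on a carbonyl carbon for (3-(trifluoromethyl)phenyl)amino gives an at least 9.7-fold lower number from compound 1 to compound 3 (0.98 log units; beyond the scatter), the only single-place step among the compounds shown and the first direct evidence that this position affects growth inhibition. Compound 1 gives only a limit, > 32500 nM. The step therefore sets a minimum size and not an exact difference, and the true gap between the two compounds remains unknown: the limit of > 32500 nM in this assay, at which 1 of the 3 values shown sits.

The change replaces the amide-type link with one carrying an added amino nitrogen and a hydrogen-bond donor, and it also removes the chlorine from the aromatic ring, so the compounds shown do not separate the contribution of the amino nitrogen from that of the chlorine. Also open, on these data alone, is how growth inhibition responds to other groups on that carbonyl carbon, such as a cyclohexylamino group, a benzyloxy group or a simple alkyl chain, and whether a 4-chloro-3-(trifluoromethyl)phenylamino group would retain the gain seen with compound 3.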